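A Piperazine Swap on the Carbonyl of Compound 1

The source may hold more compounds than are shown below. What is called first, only, known or untested is meant among the compounds shown, and "the series" means these compounds.

Compound 1 `Cc1c(C(C)C)c(=O)on1C(=O)N1CCCCC1` gives the lowest number of the three compounds in an assay (strain Wistar) for inhibition of Hormone-sensitive lipase (Rattus norvegicus), read by spectrophotometry (a higher number here means a weaker inhibitor, a lower number a stronger inhibitor), at 2 nM. Compound 2 `Cc1c(C(C)(C)C)c(=O)on1C(=O)N1CCCCC1` gives 14 nM, and compound 3 `Cc1c(C2CCCC2)c(=O)on1C(=O)N1CCCCC1` gives 6 nM, so both steps from compound 1 go to higher numbers, a 7.0-fold higher number from compound 1 to compound 2 (0.85 log units; beyond the scatter) and a 3.0-fold higher number from compound 1 to compound 3 (0.48 log units; beyond the scatter). Compound 4 `Cc1c(C(C)C)c(=O)on1C(=O)N1CCNCC1` differs from compound 1 at a different place: piperazin-1-yl in place of piperidin-1-yl on a carbonyl carbon. Going by the values given here, none of the measured steps touches the carbonyl carbon or its ring, so nothing measured bears on this change, and an expectation for compound 4 rests on the change alone. Among the compounds with values here, because compound 1 gives 2 nM and no step here exceeded a modest size, compound 4 is expected to stay near it, with a modest rise to higher numbers allowed; the estimate is 8 nM, between 2 nM and 40 nM, meaning a 4.0-fold higher number from compound 1 to compound 4 (0.60 log units; beyond the scatter).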

Compound 4, half-maximal inhibitory concentration: > 1000 nM
Compound 4: only a limit was reported; the forecaster's own chance of this, stated with the estimate: 3%; at least 120-fold (2.09 log units) between middle value and limit.
By their numbers in this assay, from the lowest: compound 1; then compound 3; then compound 2. At a limit, above all of these: compound 4.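

Piperazin-1-yl in place of piperidin-1-yl on a carbonyl carbon gives an at least 500-fold higher number from compound 1 to compound 4 (2.69 log units; beyond the scatter) in this assay, a large step, whereas the steps among isopropyl, tert-butyl and cyclopentyl stayed modest. Both groups are six-membered non-aromatic rings, so a change of hetero atoms within that ring is enough for this step. The value of compound 4 is a limit: the limit of > 1000 nM in this assay, at which 1 of the 4 values shown sits.

From the compounds shown here alone, what stays open is whether the added ring nitrogen or its hydrogen goes with this step. Morpholin-4-yl or 4-methylpiperazin-1-yl on the same carbonyl carbon would speak to that.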